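A dicoumarol pair compared on tumour cell growth

The source may hold more compounds than are shown below. What is called first, only, known or untested is meant among the compounds shown, and "the series" means these compounds.

Compound 1 `CC1(C)CC(=O)C2=C(C1)OC(N)=C(C#N)C2c1ccc(S(C)(=O)=O)cc1` is reported in a functional assay on 4T1 cells (Mus musculus) for antiproliferative activity, read by MTT assay, with a stated time of 48 h (on this read-out lower numbers stand for stronger inhibition and higher numbers for weaker inhibition), only as a limit, > 300 ug/mL, and not as a number (the limit of > 300 ug/mL in this assay, at which 1 of the 2 values shown sits). Within the data shown here, compound 2 `N#Cc1ccc(C(c2c(O)c3ccccc3oc2=O)c2c(O)c3ccccc3oc2=O)cc1` gives the single number available, 51.5 ug/mL, in this assay. Compound 3 `O=c1oc2ccccc2c(O)c1C(c1ccc(F)c(F)c1)c1c(O)c2ccccc2oc1=O` is not yet measured; it differs from compound 2 by 3,4-difluorophenyl in place of 4-cyanophenyl on a saturated chain carbon bound to two aromatic carbons. Among the measured compounds shown here, with no measured step of this kind to lean on, the account expects the shift a 1.1-fold lower number from compound 2 to compound 3 (0.06 log units; within the scatter) to stay within the scatter of repeated measurements. For compound 3 the estimated value in this assay is 45 ug/mL, with a range from 20 ug/mL to 110 ug/mL.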

Compound 3, half-maximal inhibitory concentration: 47.9 ug/mL
Compound 3: middle estimate off by 1.1-fold (0.03 log units), on the low side; the range from low to high includes it.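

In this assay, the exchange on a saturated chain carbon bound to two aromatic carbons gives a 1.1-fold lower number from compound 2 to compound 3 (0.03 log units; within the scatter), so 3,4-difluorophenyl and 4-cyanophenyl cannot be told apart at this place, even though the nitrile gives way to fluorine. The earlier compounds shown here offered no step at this place. No measurement shown gives a reason for this result. Going by these compounds, whether an aminophenyl or a carboxyphenyl in the same place would read alike stays open, and so does any change to the shared core.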